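A Hydroxy Group Enters Compound 1: What to Expect

The source may report more compounds than this note shows. Statements on the series, on what has been measured and on what is new or still open speak of the compounds shown alone.

Measured so far:
compound 1, `COc1ccc(C=C2C(=O)OC(C)(C)OC2=O)cc1` — 9.26%
compound 2, `COc1ccc(C=C2C(=O)OC(C)(C)OC2=O)c(OC)c1OC` — 13%

In a functional assay, with a stated time of 12 h, tested at 100 uM (a lower number here means less inhibition, a higher number more inhibition at the concentration tested (going by the name of the read-out)), compound 1 gives 9.26%, the lowest of the two numbers recorded. Compound 2 gives 13% in this assay, a number only a few points higher, and that gap lies within the usual scatter of repeated measurements, so the two compounds cannot be told apart on this evidence. Both read-outs are small, meaning little inhibition at the concentration tested. Among the measured compounds shown here, no pair of measured compounds differs in just one place, so there is no single measured step to serve as a yardstick.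

Compound 3, `COc1ccc(C=C2C(=O)OC(C)(C)OC2=O)cc1O`, differs from compound 1 by a single change: hydroxy in place of hydrogen on an aromatic carbon. With both measured values sitting low and close together, there is no basis for expecting a large move in either direction; the step expected in this assay is a number 2.7 percentage points higher from compound 1 to compound 3 (within the scatter), which stays within the scatter. Compound 3 is therefore estimated to give 12%, with a likely range from 2% to 26%.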

Compound 3, a percentage reported as inhibition, at one concentration (the size of the read-out at that concentration, not a potency): 52.8%
For compound 3 the middle estimate is 40.8 percentage points below the measured one; measured number outside the range, above it.
By their numbers in this assay, from the lowest: compounds 1 and 2 (each within the scatter of the next); then compound 3.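

Replacing one hydrogen with hydroxy on an aromatic carbon, ortho to a methoxy group and meta to a large group, changes the result in this assay sharply: the step is a number 43.5 percentage points higher from compound 1 to compound 3 (beyond the scatter) and is large for so small an edit. Among the compounds shown here, this is the first measured single change in the set, and it shows that this position on the six-membered aromatic ring is not a silent spot, since one added oxygen, with its one hydrogen-bond donor and one hydrogen-bond acceptor, turns little inhibition at the concentration tested into a clear read-out. Nothing shown here explains the rise, so it stands as an observation and not as a mechanism.

On these data alone, whether the rise depends on hydroxy itself stays open, as compound 1 and compound 3 alone cannot say what an amine, a carboxylic acid or a longer chain such as ethoxy would do at the same position. As far as these compounds go, it also stays open whether hydroxy would give a similar number elsewhere on the ring, or whether the methoxy group of compound 3 is needed for the effect.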